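The source may hold more compounds than are shown below. What is called first, only, known or untested is meant among the compounds shown, and "the series" means these compounds.

Measured so far:
Compound 1 `C=CCCCCOc1ccccc1-c1cnc(OCCC=C)n1C`: 33000 nM
Compound 2 `C=CCCCCOc1ccc(OC)cc1-c1cnc(OCCC=C)n1C`: 67000 nM

In a functional assay on U-373MG ATCC cells (Homo sapiens) for inhibition, read by colorimetric assay and MTT assay, with a stated time of 72 h (a lower number here means a stronger inhibitor, a higher number a weaker inhibitor), compound 1 gives 33000 nM, the lower of the two numbers, and compound 2 gives 67000 nM. Compound 3 `C=CCCCCOc1ccccc1-c1cnc(S(=O)(=O)c2ccccc2)n1C` has not yet been measured. It keeps the core of compound 1 but carries phenylsulfonyl in place of (but-3-en-1-yl)oxy on an aromatic carbon.

For the measured compounds named here, only one measured step is available, a 2.0-fold higher number from compound 1 to compound 2 (0.31 log units; beyond the scatter). It is modest and involves methoxy in place of hydrogen on an aromatic carbon, so it bears only indirectly on this change. Going by the values given here, no measurement yet shows what an exchange of the (but-3-en-1-yl)oxy group does, so no direction can be favoured. The best guess is therefore no step beyond the scatter, with wide uncertainty. The estimate means an expected 1.1-fold lower number from compound 1 to compound 3 (0.04 log units; within the scatter). For compound 3 the estimated value is 30000 nM, with an expected range from 8000 nM to 100000 nM.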

Compound 3, half-maximal inhibitory concentration: 63000 nM
For compound 3 the middle estimate is 2.1-fold (0.32 log units) below the measured one; low and high end bracket the measured number.
By their numbers in this assay, from the lowest: compounds 1, 3 and 2 (each within the scatter of the next, the first and the last beyond it).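

For the compounds shown here, this is the first measured exchange on the aromatic carbon between two ring nitrogen atoms, and in this assay replacing (but-3-en-1-yl)oxy with phenylsulfonyl gives a 1.9-fold higher number from compound 1 to compound 3 (0.28 log units; within the scatter), with the core of compound 1 otherwise unchanged. The result shows that this position can carry either a chain with a double bond or a larger group with a six-membered aromatic ring, with no step beyond the scatter in this assay. Nothing available accounts for this result.

The compounds shown leave open whether an amine, a carboxylic acid or a simple methyl group at this position would move the number beyond the scatter. They also leave open whether a longer chain there would do so.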